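Biphenyl replacement at the benzylic aryl position, compound 3

The compounds below may be only part of what the source reports. "The series", "measured", "known", "first", "only" and "open" are said of these compounds alone.

Compound 2 `CCCCNc1nc(N)nc2c1CN(Cc1ccc(C(F)(F)F)cc1)CC2` gives 0.23 uM in an assay on HEK293 cells for agonist activity at Toll-like receptor 8 (Homo sapiens), read by a luciferase reporter, with a stated time of 6 h; on this read-out lower numbers stand for an effect already at smaller amounts and higher numbers for an effect only at larger amounts of compound. Within the data shown here, it holds the lowest of the two numbers so far, though its nearest neighbour, compound 1 `CCCCNc1nc(N)nc2c1CN(Cc1ccc(OC(F)(F)F)cc1)CC2` with 0.24 uM in this assay, sits within the scatter: the step of a 1.0-fold lower number from compound 1 to compound 2 (0.02 log units; within the scatter) changes nothing that can be read.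

Compound 3 `CCCCNc1nc(N)nc2c1CN(Cc1ccc(-c3ccccc3)cc1)CC2` is not yet measured in this assay. It differs from compound 2 by phenyl in place of trifluoromethyl on an aromatic carbon, on an aromatic carbon of a six-membered aromatic ring of carbon only, para to a large group.

Among the measured compounds shown here, the only step in hand swaps two small groups at that same place and stays within the scatter, so the position has tolerated one change, but no step covers a group as large as phenyl entering there. For the measured compounds named here, no precedent bears directly on the present change; the expectation rests only on the position having accepted one swap without a shift beyond the scatter.

For compound 3 in this assay the estimate is 0.45 uM, within 0.12 uM to 1.8 uM, a step of a 2.0-fold higher number from compound 2 to compound 3 (0.29 log units; within the scatter) that is expected to stay near or just beyond the scatter.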

Compound 3, minimum effective concentration: 0.5 uM
Compound 3: the middle estimate sits 1.1-fold (0.05 log units) below what was measured; the range from low to high includes it.
By their numbers in this assay, from the lowest: compounds 2 and 1 (each within the scatter of the next); then compound 3.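

Phenyl in place of trifluoromethyl brings a 2.2-fold higher number from compound 2 to compound 3 (0.34 log units; beyond the scatter) and phenyl in place of trifluoromethoxy brings a 2.1-fold higher number from compound 1 to compound 3 (0.32 log units; beyond the scatter) on the same aromatic carbon, para to a large group, in this assay and these are the first steps at this place to lie beyond the scatter. The swap between the two fluorine-bearing groups had shown only that this place tolerates an exchange of one for the other; it now also reads a difference between either of them and phenyl, though both steps are modest and a whole aromatic ring is accepted there without a large shift. No measurement at hand accounts for the size of these steps.

Open, as far as these compounds go, is whether the shift follows from the aromatic ring itself or from the larger count of heavy atoms, which a cyclohexyl ring or a methyl group at the same place could help to separate. Also open, from the compounds shown here alone, is how a group carrying an amine or a carboxylic acid, or a phenyl bearing a further substituent, would read at this position.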